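Adding a Chloro to Compound 2

The source may hold more compounds than are shown below. What is called first, only, known or untested is meant among the compounds shown, and "the series" means these compounds.

Going by the values given here, two related compounds have numbers so far in a functional assay on KB cells (Homo sapiens) for antiproliferative activity, read by colorimetric assay and MTT assay; a higher number here means a weaker inhibitor, a lower number a stronger inhibitor. Compound 1 `O=S(=O)(Nc1cccc2cc[nH]c12)c1ccc(Cl)cc1` gives 6 ug/mL, while compound 2 `O=[N+]([O-])c1ccc(S(=O)(=O)Nc2cccc3cc[nH]c23)cc1` gives 15 ug/mL, the higher number of the pair and so the weaker inhibitor. Compound 3 `O=[N+]([O-])c1ccc(S(=O)(=O)Nc2cccc3cc(Cl)[nH]c23)cc1` keeps everything in compound 2 but adds one group: chloro in place of hydrogen on an aromatic carbon. Among the compounds with values here, only one measured step bears on this, and only loosely: a 2.5-fold higher number from compound 1 to compound 2 (0.40 log units; beyond the scatter), a modest change that came from nitro in place of chloro on an aromatic carbon. That step lies at another place in the molecule, so it offers a rough guide to size and no firm guide to direction. A similarly modest step towards a lower number in this assay is therefore expected, though with little certainty. The expected step is a 1.7-fold lower number from compound 2 to compound 3 (0.22 log units; within the scatter). For compound 3 the estimated value is 9 ug/mL, with an expected range of 2 ug/mL to 30 ug/mL.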

Compound 3, half-maximal inhibitory concentration: 18 ug/mL
For compound 3 the middle estimate is 2.0-fold (0.30 log units) below the measured one; the range from low to high includes it.
By their numbers in this assay, from the lowest: compound 1; then compounds 2 and 3 (each within the scatter of the next).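

Chloro in place of hydrogen on this aromatic carbon, next to the ring nitrogen, gives a 1.2-fold higher number from compound 2 to compound 3 (0.08 log units; within the scatter) in this assay, so compound 2 and compound 3 cannot be told apart in this read-out. Going by these compounds alone, this is the first measured step at this place in the molecule, as the earlier step concerned the nitro and chloro groups elsewhere, and it shows that a single chlorine can be added here without a change that rises above the scatter. Nothing at hand gives a reason for this result.

As far as these compounds go, whether this place tolerates other groups stays open, since a methyl, an amine or a carboxylic acid here might shift the number much further. Also open, from the compounds shown here alone, is whether chloro here would act the same way in compound 1, where chloro stands in place of nitro.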